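Amide-nitrogen substituent series, compound 4 pending

The source may report more compounds than this note shows. Statements on the series, on what has been measured and on what is new or still open speak of the compounds shown alone.

Measured so far in a functional assay, with a stated time of 20 min, tested at 2 mg/mL; a higher number here means a stronger effect of the compound at the concentration tested, a lower number a weaker effect:
compound 1, `CC(C)[C@@H]1CC[C@@H](C)C[C@@]12N(C)C(=O)[C@@H]1[C@H]3C(=O)NC(=O)[C@H]3ON12`: 58.7%
compound 2, `CC(C)[C@@H]1CC[C@@H](C)C[C@@]12N(C)C(=O)[C@@H]1[C@H]3C(=O)N(C)C(=O)[C@H]3ON12`: 53.4%
compound 3, `CC(C)[C@@H]1CC[C@@H](C)C[C@@]12N(C)C(=O)[C@@H]1[C@H]3C(=O)N(c4ccccc4)C(=O)[C@H]3ON12`: 74.2%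

Compound 3 stands highest of the three in this assay, with compound 1 nearest and compound 2 furthest, both steps beyond the scatter. Compound 4, `CC(C)[C@@H]1CC[C@@H](C)C[C@@]12N(C)C(=O)[C@@H]1[C@H]3C(=O)N(c4ccc(Cl)cc4)C(=O)[C@H]3ON12`, differs from compound 3 by chloro in place of hydrogen on an aromatic carbon. The steps measured so far all change the group on the amide-type nitrogen in a ring: a number 5.3 percentage points lower from compound 1 to compound 2 (within the scatter), a number 15.5 percentage points higher from compound 1 to compound 3 (beyond the scatter), a number 20.8 percentage points higher from compound 2 to compound 3 (beyond the scatter). None alters the phenyl itself, so none bears directly on the present change; they show only modest movement across this series. For compound 4 no step beyond the scatter is expected, a number 1.8 percentage points higher from compound 3 to compound 4 (within the scatter). Compound 4 is thus estimated at 76%, in the range 62% to 90%.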

Compound 4, a percentage reported as activity, at one concentration (the size of the read-out at that concentration, not a potency): 48.2%
Estimate against measurement, compound 4: 27.8 percentage points above, and the stated range ends above it.
By their numbers in this assay, from the lowest: compounds 4, 2 and 1 (each within the scatter of the next, the first and the last beyond it); then compound 3.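

In this assay, the phenyl ring itself proves sensitive: chloro in place of hydrogen, para to a large group, gives a number 26 percentage points lower from compound 3 to compound 4 (beyond the scatter), so the change on the aromatic carbon outweighs the earlier gain from phenyl on the amide-type nitrogen. Replacing the smaller substituents on that nitrogen with 4-chlorophenyl gives a number 5.2 percentage points lower from compound 2 to compound 4 (within the scatter) and a number 10.5 percentage points lower from compound 1 to compound 4 (beyond the scatter). No measurement available here explains the drop. On these data alone, whether fluoro, methoxy or an amine at the same place on the phenyl would also lower the number remains open.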